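Cytotoxicity notes: from compound 3 to compound 4

The source may hold more compounds than are shown below. What is called first, only, known or untested is meant among the compounds shown, and "the series" means these compounds.

Of the compounds shown here, three have been read so far in an ADME assay on MT4 cells (Homo sapiens) for cytotoxicity, read by MTT assay, with a stated time of 5 days; on this read-out higher numbers stand for lower toxicity in this test and lower numbers for higher toxicity in this test. Compound 1 (`COc1cc2nc(Nc3ccc(C#N)cc3)nc(Nc3c(C)cc(/C=C/C#N)cc3F)c2cc1OC`) gives > 52000 nM, which is a limit of the assay and not a number. Among the compounds with values here, compound 2 (`COc1cc2nc([S+]([O-])CC(=O)Nc3ccc(F)cc3)nc(Nc3c(C)cc(/C=C/C#N)cc3C)c2cc1OC`) gives 27400 nM, the one measured number among the three. Compound 3 (`COc1cc2nc([S+]([O-])CC(=O)Nc3ccccc3F)nc(Nc3c(Cl)cc(/C=C/C#N)cc3Cl)c2cc1OC`) gives > 208000 nM, which is also a limit and not a number. The standing of compound 3 is therefore known only as the limit of > 208000 nM in this assay, at which 1 of the 3 values shown sits.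

Compound 4 (`COc1cc2nc([S+]([O-])CC(=O)Nc3cccc(S(N)(=O)=O)c3)nc(Nc3c(Cl)cc(/C=C/C#N)cc3Cl)c2cc1OC`) has not yet been measured. It differs from compound 3 as follows: 3-sulfamoylphenyl in place of 2-fluorophenyl on an amide-type nitrogen. In words, 3-sulfamoylphenyl stands in place of 2-fluorophenyl on an amide-type nitrogen. Within the data shown here, no measured pair isolates this change, and the starting point is only a limit. Compound 2 also carries an amide-type nitrogen and reads 27400 nM, so a measurable number remains possible for compound 4. In this assay the expected change is a moderate move toward lower numbers, or none beyond the scatter, and the step expected is an at least 2.3-fold lower number from compound 3 to compound 4 (0.36 log units; beyond the scatter). Another limit would not be surprising. The estimate for compound 4 is 90000 nM, with an expected range from 25000 nM to 230000 nM.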

Compound 4, half-maximal cytotoxic concentration: 67800 nM
Estimate against measurement, compound 4: 1.3-fold (0.12 log units) above; low and high end bracket the measured number.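

In this assay, within the data shown here, 3-sulfamoylphenyl in place of 2-fluorophenyl on an amide-type nitrogen gives an at least 3.0-fold lower number from compound 3 to compound 4 (0.48 log units; beyond the scatter), the first step that isolates a single place. As far as these compounds go, the true size of this step remains unknown because compound 3 stands only as a limit of the assay and not a number: the limit of > 208000 nM in this assay, at which 1 of the 4 values shown sits. The direction is still informative: this place is not silent in this assay, as a change here alone, with the rest of the structure kept, brings the read-out from a limit to a measured number. Compound 4 gives 67800 nM.

This single pair does not separate the arrival of the sulfamoyl group from the loss of the fluorine, nor does it show whether the substituent's place on the phenyl ring matters. From the compounds shown here alone, how a carboxylic acid or an aminomethyl group would read at this place in this assay remains open, as does whether the same exchange would give a similar step in the setting of compound 2.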